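The compounds below may be only part of what the source reports. "The series", "measured", "known", "first", "only" and "open" are said of these compounds alone.

Working notes on the series. Among the measured compounds shown here, compound 2 `Brc1ccc(-c2cn3ccnc3c(-c3ccc4ncn(C5CCCCC5)c4c3)n2)cc1` gives 13.2% in a functional assay on OVCAR-8 cells (Homo sapiens) for inhibition, read by sulforhodamine B assay, with a stated time of 48 h, tested at 10 uM (on this read-out higher numbers stand for more inhibition at the one concentration tested (going by the name of the read-out) and lower numbers for less inhibition), the higher of the two numbers measured so far, though within the scatter of compound 1 `CC(=O)c1ccc(-c2cn3ccnc3c(-c3ccc4ncn(C5CCCCC5)c4c3)n2)cc1`, which gives 6.38%. Compound 3 `COc1ccccc1-c1cn2ccnc2c(-c2ccc3ncn(C4CCCCC4)c3c2)n1` carries 2-methoxyphenyl in place of 4-bromophenyl on an aromatic carbon. For the measured compounds named here, the only measured step that bears on this change is the exchange of one group on the phenyl ring, a number 6.8 percentage points higher from compound 1 to compound 2 (within the scatter), a step within the scatter, so for compound 3 no step beyond the scatter is expected in this assay, a number 3.2 percentage points lower from compound 2 to compound 3 (within the scatter). Compound 3 is therefore estimated at 10%, between -5% and 28%.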

Compound 3, a percentage reported as inhibition, at one concentration (the size of the read-out at that concentration, not a potency): 8.78%
Compound 3: middle estimate off by 1.2 percentage points, on the high side; measured number inside the range.
By their numbers in this assay, from the lowest: compounds 1, 3 and 2 (each within the scatter of the next).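

In this assay the exchange of 4-bromophenyl for 2-methoxyphenyl on this aromatic carbon stays within the scatter (a number 4.4 percentage points lower from compound 2 to compound 3 (within the scatter)), as does the exchange of 4-acetylphenyl for 2-methoxyphenyl (a number 2.4 percentage points higher from compound 1 to compound 3 (within the scatter)). The three substituted phenyl groups at this place are therefore not told apart by this read-out, even with the methoxy group's oxygen entering. No measurement bears on why this is so. As far as these compounds go, whether an amine or a carboxylic acid on the phenyl ring would give a step beyond the scatter stays open. Also open, from the compounds shown here alone, is how 4-methoxyphenyl would compare with 2-methoxyphenyl here.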